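This account rests on a few compounds, and the source may have more. Where it says the series, first, only, none or still open, it means among the compounds named here.

In a functional assay on HCT-116 cells (Homo sapiens) for cytotoxicity, read by MTT assay, with a stated time of 72 h (on this read-out higher numbers stand for weaker inhibition and lower numbers for stronger inhibition), three compounds sharing one core have been measured: compound 1 `O=C1c2c[n+]([O-])c3ccccc3c2C(=O)c2c1c1ccccc1n2CCCCn1ccnc1` gives 240 nM, compound 2 `O=C1c2c[n+]([O-])c3ccccc3c2C(=O)c2c1c1ccccc1n2CCN1CCCC1` gives 270 nM and compound 3 `CCCN1CCN(CCCCn2c3c(c4ccccc42)C(=O)c2c[n+]([O-])c4ccccc4c2C3=O)CC1` gives 790 nM. Compound 3 therefore has the highest number of the three, which makes it the weakest inhibitor of the set. Compound 4 `O=C1c2c[n+]([O-])c3ccccc3c2C(=O)c2c1c1ccccc1n2Cc1cn(C[C@@H](O)CO)nn1` departs from compound 3 on a saturated chain carbon bound to an aromatic nitrogen: 1-(2,3-dihydroxypropyl)-1H-1,2,3-triazol-4-yl in place of 3-(4-propylpiperazin-1-yl)propyl on a saturated chain carbon bound to an aromatic nitrogen. Among the compounds with values here, no measured compound carries the entering 1-(2,3-dihydroxypropyl)-1H-1,2,3-triazol-4-yl group, so the measured steps offer only indirect guidance. The step of a 1.1-fold higher number from compound 1 to compound 2 (0.05 log units; within the scatter) shows that two quite different chain ends can give values within the scatter of each other. Within the data shown here, the only steps beyond the scatter lead to compound 3, the one compound bearing the propylpiperazine: a 3.3-fold higher number from compound 1 to compound 3 (0.52 log units; beyond the scatter) and a 2.9-fold higher number from compound 2 to compound 3 (0.47 log units; beyond the scatter). Both are modest, so a modest move towards the values of compound 1 and compound 2 is expected in this assay once that group is gone, with considerable uncertainty. The expected change is a 2.1-fold lower number from compound 3 to compound 4 (0.32 log units; beyond the scatter). For compound 4 the estimated value is 380 nM, with an expected range from 130 nM to 1100 nM.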

Compound 4, half-maximal inhibitory concentration: 190 nM
For compound 4 the middle estimate is 2.0-fold (0.30 log units) above the measured one; measured number inside the range.
By their numbers in this assay, from the lowest: compounds 4, 1 and 2 (each within the scatter of the next); then compound 3.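

In this assay, the step of a 4.2-fold lower number from compound 3 to compound 4 (0.62 log units; beyond the scatter) lies beyond the scatter, showing that replacing 3-(4-propylpiperazin-1-yl)propyl on a saturated chain carbon bound to an aromatic nitrogen with 1-(2,3-dihydroxypropyl)-1H-1,2,3-triazol-4-yl restores a number in the range of the other two compounds. The steps of a 1.4-fold lower number from compound 2 to compound 4 (0.15 log units; within the scatter) and a 1.3-fold lower number from compound 1 to compound 4 (0.10 log units; within the scatter) both lie within the scatter, so this place accepts a third, quite different group, one with a five-membered aromatic ring, hydrogen-bond donors and a defined stereocentre, without a change that can be read, and among these four compounds only compound 3 stands apart. No information is available here to explain this tolerance or the separate position of compound 3.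

The compounds shown leave open whether the higher number of compound 3 goes with the piperazine ring or with its propyl group, a question that an unsubstituted piperazine or a morpholine on the same chain would address. They also leave open whether the two hydroxyl groups of compound 4 matter, which a simple methyl group on the triazole or the opposite configuration at the stereocentre would address.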